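From pyridin-3-yl to pyridin-4-yl on a shared core

The source may report more compounds than this note shows. Statements on the series, on what has been measured and on what is new or still open speak of the compounds shown alone.

Of the compounds shown here, three sharing one core have been measured in an ADME assay on microsomes (Mus musculus) for metabolic stability (a lower number here means slower removal, a higher number faster removal of the compound), so far. Compound 1 `CNC(=O)[C@@H]1CCCN1S(=O)(=O)c1ccc(Cl)c(COc2cccc3c(-n4ccnc4)cc(C)nc23)c1Cl` gives 267 mL/min/kg as its clearance, compound 2 `CNC(=O)[C@@H]1CCCN1S(=O)(=O)c1ccc(Cl)c(COc2cccc3c(OCc4ccccc4)cc(C)nc23)c1Cl` gives 1820 mL/min/kg and compound 3 `CNC(=O)[C@@H]1CCCN1S(=O)(=O)c1ccc(Cl)c(COc2cccc3c(-c4cccnc4)cc(C)nc23)c1Cl` gives 700 mL/min/kg as its clearance, which places it second highest of the three and apart from both others. Compound 4 `CNC(=O)[C@@H]1CCCN1S(=O)(=O)c1ccc(Cl)c(COc2cccc3c(-c4ccncc4)cc(C)nc23)c1Cl` differs from compound 3 in one group, with pyridin-4-yl in place of pyridin-3-yl on an aromatic carbon is the whole change. Within the data shown here, three measured steps bear on this place. They are a 6.8-fold higher number from compound 1 to compound 2 (0.83 log units; beyond the scatter) for benzyloxy in place of 1H-imidazol-1-yl, a 2.6-fold higher number from compound 1 to compound 3 (0.42 log units; beyond the scatter) for pyridin-3-yl in place of 1H-imidazol-1-yl, and a 2.6-fold lower number from compound 2 to compound 3 (0.41 log units; beyond the scatter) for pyridin-3-yl in place of benzyloxy. All three are modest and beyond the scatter, yet none compares pyridin-3-yl with pyridin-4-yl, so the data give no direction. The expected change is smaller than those steps and stays within the scatter, as a 1.1-fold lower number from compound 3 to compound 4 (0.05 log units; within the scatter) in this assay shows. The estimate for compound 4 is 620 mL/min/kg as a middle value, expected to fall between 300 mL/min/kg and 1250 mL/min/kg when measured.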

Compound 4, clearance: 550 mL/min/kg
Estimate against measurement, compound 4: 1.1-fold (0.05 log units) above; low and high end bracket the measured number.
By their numbers in this assay, from the lowest: compound 1; then compounds 4 and 3 (each within the scatter of the next); then compound 2.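

In this assay, exchanging pyridin-3-yl for pyridin-4-yl, which keeps the same atoms and only joins them differently, gives a 1.3-fold lower number from compound 3 to compound 4 (0.10 log units; within the scatter) and so separates the two groups at this position by no more than repeat measurements would. Pyridin-4-yl also stands apart from the other two groups, with a 3.3-fold lower number from compound 2 to compound 4 (0.52 log units; beyond the scatter) and with a 2.1-fold higher number from compound 1 to compound 4 (0.31 log units; beyond the scatter) in the same assay, both steps lying beyond the scatter. Nothing measured here accounts for any of these steps.

The compounds shown leave open how a plain phenyl ring or a pyridin-2-yl group would stand on this aromatic carbon. They also leave open whether a 1H-pyrazol-1-yl group would share the lower number of compound 1.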